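A few compounds are considered here, and "the series" means these few. Any claim that something is new, unique, unknown or untested is made for them only; others in the source may bear on it.

Measured compounds and their values in a functional assay on aorta (strain Wistar) for inhibition, with Thoracic aorta (Rattus norvegicus) as the target; a higher number here means a weaker inhibitor, a lower number a stronger inhibitor:
- compound 1, `COc1ccc(-c2cc(-c3cc4ccccc4o3)nc(OC)c2C#N)c(OC)c1`: 425000 nM
- compound 2, `CCOc1nc(-c2cc3ccccc3o2)cc(-c2ccc(OC)cc2OC)c1C#N`: 488000 nM
- compound 3, `COc1nc(-c2cc3ccccc3o2)cc(-c2ccc(C)o2)c1C#N`: 285000 nM

Compound 1 and compound 2 differ by methyl in place of hydrogen on a saturated chain carbon bound to an oxygen on an aromatic ring; that change gave a 1.1-fold higher number from compound 1 to compound 2 (0.06 log units; within the scatter). Compound 3 carries a different core; the difference between the two cores is not broken down here. In this assay compound 3 gives 285000 nM, which lies within the usual scatter of the values of compound 1 and compound 2, so no order among the three is claimed.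

Compound 4, `CCOc1nc(-c2cc3ccccc3o2)cc(-c2ccc(C)o2)c1C#N`, has not been measured. It differs from compound 3 by methyl in place of hydrogen on a saturated chain carbon bound to an oxygen on an aromatic ring, the same change as from compound 1 to compound 2. Among the compounds with values here, the step is expected to be a 1.1-fold higher number from compound 3 to compound 4 (0.04 log units; within the scatter), resting on the one earlier example of this change, a 1.1-fold higher number from compound 1 to compound 2 (0.06 log units; within the scatter); with only one pair to go on, the range is kept wide. The value of compound 4 in this assay is estimated at 310000 nM, between 150000 nM and 650000 nM.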

Compound 4, half-maximal inhibitory concentration: 417000 nM
For compound 4 the middle estimate is 1.3-fold (0.13 log units) below the measured one; low and high end bracket the measured number.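

In this assay, methoxy to ethoxy on the core of compound 3 gives a 1.5-fold higher number from compound 3 to compound 4 (0.17 log units; within the scatter). The step reads alike on the two cores: the same change on two cores in this assay, a 1.1-fold higher number (0.06 log units; within the scatter) from compound 1 to compound 2 and a 1.5-fold higher number (0.17 log units; within the scatter) from compound 3 to compound 4, 1.3-fold (0.11 log units) apart, within the scatter of two such steps. This shows that the step stays within the scatter on both cores, but two pairs establish neither an effect of the ethoxy group nor a rule for other cores, and the step with 5-methylfuran-2-yl in place of 2,4-dimethoxyphenyl, a 1.2-fold lower number from compound 2 to compound 4 (0.07 log units; within the scatter), also stays within the scatter.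

Open, going by these compounds, is whether a longer chain such as propoxy, or an amine at the end of that chain, would give a step beyond the scatter. Also open, on these data alone, is how the step reads on cores other than these two.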